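The source may report more compounds than this note shows. Statements on the series, on what has been measured and on what is new or still open speak of the compounds shown alone.

Measured compounds:
Compound 1, `CCNC(=O)N1CCN(C(=S)SCc2cn(Cc3ccc(F)cc3)nn2)CC1`: in a functional assay on EC9706 cells (Homo sapiens) for cytotoxicity, read by MTT assay, with a stated time of 72 h (a higher number here means a weaker inhibitor, a lower number a stronger inhibitor), compound 1 gives 27800 nM.
Compound 2, `CC(C)NC(=O)N1CCN(C(=S)SCc2cn(Cc3ccc(F)cc3)nn2)CC1`: in this assay compound 2 gives 12200 nM.
Compound 3, `CCNC(=O)N1CCN(C(=S)SCc2cn(Cc3ccc(C)cc3)nn2)CC1`: in this assay compound 3 gives > 128000 nM, which is a limit of the assay and not a number.

Compound 1 and compound 2 share one core and differ in a single spot: methyl in place of hydrogen on a saturated chain carbon bound to an amide-type nitrogen and a saturated chain carbon. This change gives a 2.3-fold lower number from compound 1 to compound 2 (0.36 log units; beyond the scatter). Compound 3 has a different core from compound 1, and the difference between the two cores is methyl in place of fluoro on an aromatic carbon. That difference gives an at least 4.6-fold higher number from compound 1 to compound 3 (0.66 log units; beyond the scatter). The step toward compound 3 ends at the limit of > 128000 nM in this assay, at which 1 of the 3 values shown sits, so the true value of compound 3 is not known.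

Compound 4, `Cc1ccc(Cn2cc(CSC(=S)N3CCN(C(=O)NC(C)C)CC3)nn2)cc1`, is not yet measured. It stands to compound 3 as compound 2 stands to compound 1: methyl in place of hydrogen on a saturated chain carbon bound to an amide-type nitrogen and a saturated chain carbon. The place is described in the same words for both pairs, so this is the same change made within a second core. For compound 4 in this assay, the expected step is an at least 1.1-fold lower number from compound 3 to compound 4 (0.06 log units; that floor lies within the scatter), by analogy with a 2.3-fold lower number from compound 1 to compound 2 (0.36 log units; beyond the scatter). The value of compound 3 is only a limit. The starting point for compound 4 is thus uncertain, and compound 4 may itself return a limit. Compound 4 is estimated at 110000 nM, with a range from 40000 nM to 300000 nM.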

Compound 4, half-maximal inhibitory concentration: > 128000 nM
Compound 4: only a limit was reported; the forecaster's own chance of this, stated with the estimate: 55%; at least 1.1-fold (0.06 log units) between middle value and limit.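

In this assay compound 4 gives > 128000 nM, which is a limit of the assay and not a number, and compound 3 also sits at a limit, so the step for ethyl to isopropyl on this core cannot be read: the limit of > 128000 nM in this assay, at which 2 of the 4 values shown sit.

The one new step that can be read is methyl in place of fluoro on an aromatic carbon, which gives an at least 10-fold higher number from compound 2 to compound 4 (1.02 log units; beyond the scatter), and it can be set beside the same change on the other core: the same change on two cores in this assay, an at least 4.6-fold higher number (0.66 log units; beyond the scatter) from compound 1 to compound 3 and an at least 10-fold higher number (1.02 log units; beyond the scatter) from compound 2 to compound 4; the limit leaves it open whether they differ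

So this change moves the number in the same direction on both cores, with no compound shown going against that, but the data do not show how large it truly is on either core, nor whether the step of a 2.3-fold lower number from compound 1 to compound 2 (0.36 log units; beyond the scatter) carries over to the core of compound 3.

The compounds shown leave open how far compound 3 and compound 4 really lie past the limit, and thus whether isopropyl in place of ethyl changes anything when methyl replaces fluoro. As far as these compounds go, it also remains open how a chloro group on that aromatic carbon, or a longer chain such as butyl in place of isopropyl, would behave in this assay.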